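Exchanging the imidazole for a piperidine on the anilino ring

The source may report more compounds than this note shows. Statements on the series, on what has been measured and on what is new or still open speak of the compounds shown alone.

Measured compounds:
compound 1, `Cc1cn(-c2ccc(Nc3nccc(-c4ccncc4)n3)cc2)cn1`: > 3000 nM
compound 2, `CCc1cccc(Nc2nccc(-c3ccsc3)n2)c1`: 1100 nM
compound 3, `CN(c1ccccc1)c1nccc(-c2ccncc2)n1`: > 24000 nM

Of the compounds shown here, three sharing the anilino-pyrimidine core have been measured in a functional assay for inhibition, with Homo sapiens as the target; on this read-out lower numbers stand for stronger inhibition and higher numbers for weaker inhibition. Among the measured compounds shown here, compound 2 is the only one with a proper number, giving 1100 nM. For compound 1 the read-out is a limit rather than a number, > 3000 nM, so it sits at the limit of > 3000 nM in this assay, at which 1 of the 3 values shown sits. Compound 3 is likewise reported only as a limit, > 24000 nM, which is the limit of > 24000 nM in this assay, at which 1 of the 3 values shown sits. For the measured compounds named here, no pair of these three differs in a single place, so no measured step is available, and compound 1 can only be said to be weak or inactive within the range tested.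

Compound 4, `CC1CCN(c2ccc(Nc3nccc(-c4ccncc4)n3)cc2)CC1`, is the unmeasured analogue of compound 1. It differs by 4-methylpiperidin-1-yl in place of 4-methyl-1H-imidazol-1-yl on an aromatic carbon. Going by the values given here, with no measured step to lean on, the size of the change from compound 1 to compound 4 is uncertain; a modest step toward stronger inhibition is expected, estimated as a number no higher from compound 1 to compound 4 (the limit leaves the size open), though it may not exceed the scatter. Compound 4 is therefore expected to give about 3000 nM in this assay, within a range of 600 nM to 15000 nM.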

Compound 4, half-maximal inhibitory concentration: 600 nM
Estimate against measurement, compound 4: 5.0-fold (0.70 log units) above; measured number inside the range.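

In this assay, the aromatic carbon para to a large group proves sensitive to the group it carries: 4-methylpiperidin-1-yl in place of 4-methyl-1H-imidazol-1-yl gives an at least 5.0-fold lower number from compound 1 to compound 4 (0.69 log units; beyond the scatter). With this single change, a six-membered non-aromatic ring with one hetero atom replaces a five-membered aromatic ring with two, and compound 4 gives a measured number of 600 nM, so the earlier lack of a number at this position does not extend to every group placed there. The step can be given only as a lower bound because compound 1 is reported as a limit: the limit of > 3000 nM in this assay, at which 1 of the 4 values shown sits.

The swap alters ring size, aromaticity and the number of hetero atoms at once, so the compounds shown cannot say which of these matters, nor what part the methyl group plays. From the compounds shown here alone, a morpholine, a piperazine or an unsubstituted piperidine on the same carbon would begin to separate these features, and the full size of the step stays open.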